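Amino for methyl on a weak benzimidazole inhibitor pair

The source may report more compounds than this note shows. Statements on the series, on what has been measured and on what is new or still open speak of the compounds shown alone.

Measured compounds:
compound 1, `Cc1ccc2nc(-c3ccc([N+](=O)[O-])cc3)[nH]c2c1`, gives 22000 nM
compound 2, `Cc1ccc2nc(-c3cccc([N+](=O)[O-])c3)[nH]c2c1`, gives 36600 nM

Both values come from an assay on cells for inhibition of matrix metalloproteinase-9 (Homo sapiens), read by fluorescence, with stated times of 15 min and 4 h; on this read-out lower numbers stand for stronger inhibition and higher numbers for weaker inhibition. Compound 1 has the lowest of the two numbers, but compound 2 is its nearest neighbour and the gap between them lies within the scatter, so neither can be called the more potent. Compound 3, `Nc1ccc2nc(-c3ccc([N+](=O)[O-])cc3)[nH]c2c1`, has not yet been measured in this assay. It differs from compound 1 in one place: amino in place of methyl on an aromatic carbon. Within the data shown here, no step between measured compounds covers such a change, so the direction of any shift is open; the expectation is for no step beyond the scatter, since the shared core and the nitro-substituted ring stay as they are in compound 1. For compound 3 the estimated step is a 1.1-fold lower number from compound 1 to compound 3 (0.04 log units; within the scatter) in this assay. Compound 3 is therefore expected to give about 20000 nM, with a range from 7000 nM to 60000 nM.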

Compound 3, half-maximal inhibitory concentration: > 100000 nM
Compound 3 ended at the assay's limit; the forecaster's own chance of this, stated with the estimate: 15%; at least 5.0-fold (0.69 log units) between middle value and limit.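

Compound 3 gives > 100000 nM in this assay, and this value is a limit of the assay, not a number. The earlier compounds shown here varied only the place of the nitro group, whereas this pair shows that the methyl-bearing aromatic carbon of the shared core is sensitive to substitution: amino in place of methyl, an exchange of one heavy atom for another, gives an at least 4.5-fold higher number from compound 1 to compound 3 (0.65 log units; beyond the scatter). That step can be read only as a lower bound because compound 3 sits at the limit: the limit of > 100000 nM in this assay, at which 1 of the 3 values shown sits.

The compounds shown leave open how large the true step is and whether the same exchange would matter with the nitro group placed as in compound 2. They also leave open how a hydroxyl, a methoxy, an ethyl or a plain hydrogen would fare on this carbon.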